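Deacetylation of the terminal sugar of compound 1

The compounds below may be only part of what the source reports. "The series", "measured", "known", "first", "only" and "open" are said of these compounds alone.

Compound 1 `CCCCCCCCO[C@@H]1O[C@@H](C)[C@H](OC(=O)CCCCC)[C@@H](O[C@@H]2O[C@@H](C)[C@H](OC(C)=O)[C@@H](O[C@@H]3O[C@@H](C)[C@H](OC(C)=O)[C@@H](OC(C)=O)[C@H]3O)[C@H]2OC(C)=O)[C@H]1O` is the trisaccharide of the series, with an octyl glycoside and a hexanoyl ester on the shared core and acetyl groups on the outer sugars. In a functional assay on KB cells (Homo sapiens) for cytotoxicity, in the absence of a further agent (on this read-out lower numbers stand for an effect already at smaller amounts and higher numbers for an effect only at larger amounts of compound), compound 1 gives > 20 ug/mL, which is a limit of the assay and not a number. Compound 2 `CCCCCCCCO[C@@H]1O[C@@H](C)[C@H](OC(=O)CCCCC)[C@@H](O[C@@H]2O[C@@H](C)[C@H](OC(C)=O)[C@@H](O)[C@H]2OC(C)=O)[C@H]1O` is the disaccharide with a free hydroxy on its outer sugar; in this assay compound 2 gives > 20 ug/mL, again only a limit. Compound 3 `CCCCCCCCO[C@@H]1O[C@@H](C)[C@H](OC(=O)CCCCC)[C@@H](O[C@@H]2O[C@@H](C)[C@H](OC(C)=O)[C@@H](OC(C)=O)[C@H]2OC(C)=O)[C@H]1O` carries an acetyl at that oxygen; in this assay compound 3 gives > 20 ug/mL, also a limit. Hence the step that the two limits leave unreadable from compound 2 to compound 3 cannot be sized, because of the limit of > 20 ug/mL in this assay, at which 3 of the 3 values shown sit.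

Compound 4 `CCCCCCCCO[C@@H]1O[C@@H](C)[C@H](OC(=O)CCCCC)[C@@H](O[C@@H]2O[C@@H](C)[C@H](OC(C)=O)[C@@H](O[C@@H]3O[C@@H](C)[C@H](OC(C)=O)[C@@H](O)[C@H]3O)[C@H]2OC(C)=O)[C@H]1O` differs from compound 1 by hydrogen in place of acetyl on an oxygen on a saturated carbon. Among the measured compounds shown here, the only measured step of the same kind is the unreadable one just mentioned, so no direction can be taken from the series; with every value at the limit, compound 4 is expected to remain there, an expected step that the limit leaves unreadable from compound 1 to compound 4. For compound 4 the estimate in this assay is 30 ug/mL, between 12 ug/mL and 100 ug/mL, most likely reported only as a limit.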

Compound 4, concentration for half-maximal effect: > 20 ug/mL
Compound 4 ended at the assay's limit; the forecaster's own chance of this, stated with the estimate: 85%; the middle value lies beyond the limit too.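

Compound 1 and compound 4 give no readable step in this assay, because both sit at the same limit: the limit of > 20 ug/mL in this assay, at which 4 of the 4 values shown sit.

The compounds shown leave open whether acetoxy to hydroxy, or any other change among them, alters cytotoxicity at all.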